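Adding a methyl to a benzyl substituent in a cytotoxicity series

This account rests on a few compounds, and the source may have more. Where it says the series, first, only, none or still open, it means among the compounds named here.

Compound 2 `CC(=O)OC[C@H]1O[C@@H](n2cc(-c3cn(Cc4ccc(C(C)C)cc4)nn3)c(=O)[nH]c2=O)C[C@@H]1OC(C)=O` is measured in a functional assay on HCT-15 cells (Homo sapiens) for cytotoxicity, read by sulforhodamine B assay, tested at 10 uM (a lower number here means less inhibition, a higher number more inhibition at the concentration tested (going by the name of the read-out)), where it gives 96.5%. Compound 1 `CCCCCc1cc(-c2cn([C@H]3C[C@H](OC(C)=O)[C@@H](COC(C)=O)O3)c(=O)[nH]c2=O)on1` gives 98.7%, a number within the scatter of compound 2, while compound 3 `CC(=O)OC[C@H]1O[C@@H](n2cc(-c3cc(-c4ccc(C(C)(C)C)cc4)no3)c(=O)[nH]c2=O)C[C@@H]1OC(C)=O` gives 53.8%, clearly lower. Among the compounds with values here, the only single-place step recorded is a number 44.9 percentage points lower from compound 1 to compound 3 (beyond the scatter). Compound 4 `CC(=O)OC[C@H]1O[C@@H](n2cc(-c3cn(Cc4ccc(C(C)(C)C)cc4)nn3)c(=O)[nH]c2=O)C[C@@H]1OC(C)=O` differs from compound 2 by methyl in place of hydrogen on a saturated chain carbon bound to an aromatic carbon and two saturated chain carbons. That change is not the same as the recorded step, which replaced a whole chain with an aromatic group, so it bears on the new step only loosely. The methyl addition is expected to shift this assay little, if at all beyond the scatter, giving a number 8.5 percentage points lower from compound 2 to compound 4 (within the scatter). Compound 4 is therefore estimated at 88%, within 60% to 99%.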

Compound 4, a percentage reported as inhibition, at one concentration (the size of the read-out at that concentration, not a potency): 94.2%
Estimate against measurement, compound 4: 6.2 percentage points below; low and high end bracket the measured number.
By their numbers in this assay, from the lowest: compound 3; then compounds 4, 2 and 1 (each within the scatter of the next).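

Going from 4-isopropylbenzyl to 4-(tert-butyl)benzyl in this assay gives a number 2.3 percentage points lower from compound 2 to compound 4 (within the scatter) and so the added methyl makes no change that can be told from the scatter. This is the first step shown on this benzyl substituent, and the reading stays high with either group. No measurement shown here explains this result. Still open, going by these compounds, is how this position would respond to a group of another kind, such as an amine or a carboxylic acid in place of tert-butyl.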